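Methyl added to the acid-bearing ring of compound 2

The source may hold more compounds than are shown below. What is called first, only, known or untested is meant among the compounds shown, and "the series" means these compounds.

Measured compounds:
compound 1, `CN1C[C@@H](COc2ccc(C(=O)N(C)c3cccc(CC(=O)O)c3)cc2)Oc2ccccc21`, "not determined" (no result reported)
compound 2, `CN1C[C@@H](COc2ccc(C(=O)Nc3cccc(CC(=O)O)c3)c(Cl)c2)Oc2ccccc21`, 20 nM
compound 3, `Cc1cc(OC[C@@H]2CN(C)c3ccccc3O2)ccc1C(=O)Nc1cc(F)cc(CC(=O)O)c1`, 5.6 nM

Compound 1 carries no number. In a functional assay on CHO cells for antagonist activity at prostaglandin D2 receptor (Mus musculus), read by cAMP accumulation (a higher number here means a weaker inhibitor, a lower number a stronger inhibitor), compound 2 gives 20 nM, the higher of the two numbers, and compound 3 gives 5.6 nM, a gap that lies beyond the scatter. Compound 4, `Cc1cc(CC(=O)O)cc(NC(=O)c2ccc(OC[C@@H]3CN(C)c4ccccc4O3)cc2Cl)c1`, differs from compound 2 in one place: methyl in place of hydrogen on an aromatic carbon. Going by the values given here, no pair of measured compounds shows this change in isolation, so its effect is open. A step of this kind is expected to be small, possibly a slight strengthening, but likely within the scatter, giving an estimated 1.3-fold lower number from compound 2 to compound 4 (0.12 log units; within the scatter). Compound 4 is therefore expected to reach about 15 nM, within 5 nM to 45 nM.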

Compound 4, half-maximal inhibitory concentration: 5.4 nM
Compound 4: middle estimate off by 2.8-fold (0.44 log units), on the high side; the measured number falls inside the stated range.
By their numbers in this assay, from the lowest: compounds 4 and 3 (each within the scatter of the next); then compound 2.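

In this assay, the methyl on the aromatic carbon meta to the carboxymethyl group gives a 3.7-fold lower number from compound 2 to compound 4 (0.57 log units; beyond the scatter), the first change in one place that can be read among these compounds. This carbon of the acid-bearing ring therefore accepts a methyl, and the inhibitor grows stronger by more than the scatter. Nothing available here accounts for the size of this step. As far as these compounds go, whether an amine or a methoxy group on this carbon would move the number the same way remains open, as does whether the methyl step holds beyond this one pair.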